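From 4-ethylphenyl to 2-methoxyphenyl on a shared core

The source may report more compounds than this note shows. Statements on the series, on what has been measured and on what is new or still open speak of the compounds shown alone.

Measured in a functional assay on HeLa cells (Homo sapiens) for inhibition, read by sulforhodamine B assay; on this read-out higher numbers stand for weaker inhibition and lower numbers for stronger inhibition:
- compound 1 `O=C1C(Nc2ccc(I)cc2)=CC(=O)c2c1nc1n2[C@H]2OC[C@@H](O)[C@H]2OC1`: 4010 nM
- compound 2 `CCc1ccc(NC2=CC(=O)c3c(nc4n3[C@H]3OC[C@@H](O)[C@H]3OC4)C2=O)cc1`: 6510 nM

Among the compounds with values here, compound 2 stands at 6510 nM, with only one other number to compare it with, and the two do not separate beyond the scatter. Compound 3 `COc1ccccc1NC1=CC(=O)c2c(nc3n2[C@H]2OC[C@@H](O)[C@H]2OC3)C1=O` carries 2-methoxyphenyl in place of 4-ethylphenyl on an amine nitrogen. Within the data shown here, no measured compound carries this group. Among the measured compounds shown here, the only guide is the one measured step, a 1.6-fold higher number from compound 1 to compound 2 (0.21 log units; within the scatter), which is a smaller change on the aromatic ring and stays within the scatter. No step beyond the scatter is therefore expected in this assay, and the expected step is a 1.3-fold lower number from compound 2 to compound 3 (0.11 log units; within the scatter). For compound 3 the estimated value is 5000 nM, with an expected range of 1800 nM to 13000 nM.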

Compound 3, half-maximal inhibitory concentration: 7460 nM
Estimate against measurement, compound 3: 1.5-fold (0.17 log units) below; the range from low to high includes it.
By their numbers in this assay, from the lowest: compounds 1, 2 and 3 (each within the scatter of the next).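

In this assay, 2-methoxyphenyl in place of 4-ethylphenyl on the amine nitrogen gives a 1.1-fold higher number from compound 2 to compound 3 (0.06 log units; within the scatter), and in place of 4-iodophenyl it gives a 1.9-fold higher number from compound 1 to compound 3 (0.27 log units; within the scatter). The entering group brings an oxygen and a hydrogen-bond acceptor, yet all three aromatic groups at this position stay within the scatter of one another. No evidence is available that bears on this result. Still open, going by these compounds, is whether an aromatic ring carrying an amine or a carboxylic acid would separate from these three. On these data alone, replacing the ring with a simple alkyl chain on this nitrogen is equally open.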